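The source may report more compounds than this note shows. Statements on the series, on what has been measured and on what is new or still open speak of the compounds shown alone.

Measured so far:
compound 1, `C[C@H]1O[C@H](CO)[C@@H](O)[C@H](O)[C@H]1O`, 50100000 nM
compound 2, `NCC[C@@H]1O[C@H](CO)[C@@H](O)[C@H](O)[C@H]1O`, 5010000 nM

In an assay on isolated protein (Sus scrofa) for inhibition of glycogen phosphorylase, brain form (Homo sapiens) (on this read-out lower numbers stand for stronger inhibition and higher numbers for weaker inhibition), compound 1 gives the highest number of the two; compound 2 gives a lower number, 5010000 nM, a gap beyond the usual scatter. Compound 3, `NC(=O)CS[C@H]1O[C@H](CO)[C@@H](O)[C@H](O)[C@H]1O`, is not yet measured. It differs from compound 1 by (carbamoylmethyl)sulfanyl in place of methyl on a saturated ring carbon. Since compound 1 gives 50100000 nM and compound 2, which carries a larger group on that carbon, gives a lower number, the step of a 17-fold lower number from compound 1 to compound 3 (1.22 log units; beyond the scatter) is expected to be downward and beyond the scatter. Compound 3 is therefore estimated at 3000000 nM, between 600000 nM and 20000000 nM.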

Compound 3, inhibition constant: 20000000 nM
Estimate against measurement, compound 3: 6.7-fold (0.82 log units) below, within the range that was stated.
By their numbers in this assay, from the lowest: compound 2; then compound 3; then compound 1.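

In this assay replacing methyl with (carbamoylmethyl)sulfanyl on this saturated ring carbon, next to the ring oxygen, gives a 2.5-fold lower number from compound 1 to compound 3 (0.40 log units; beyond the scatter) and so a modest step beyond the usual scatter. The position therefore accepts this larger group with its sulfur and primary amide, and the number still falls, though not by much. Nothing at hand explains the step.

The compounds shown leave open whether the sulfur or the amide accounts for the change. They also do not tell how a carboxylic acid in place of the amide, or a longer chain, would read out.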